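A few compounds are considered here, and "the series" means these few. Any claim that something is new, unique, unknown or untested is made for them only; others in the source may bear on it.

Measured in a functional assay on MIA PaCa-2 cells (Homo sapiens) for inhibition, read by MTT assay; a higher number here means a weaker inhibitor, a lower number a stronger inhibitor:
- compound 1 `COc1ccccc1NC(=O)c1cc2cnc(Nc3ccc(N4CCNCC4)cn3)nc2n1C1CCCC1`: 1830 nM
- compound 2 `COc1cccc(NC(=O)c2cc3cnc(Nc4ccc(N5CCNCC5)cn4)nc3n2C2CCCC2)c1`: 2650 nM

Going by the values given here, compound 2 gives 2650 nM, the higher of only two numbers, but the gap is within the scatter, so the pair cannot be ranked. Compound 3 `COc1ccc(NC(=O)c2cc3cnc(Nc4ccc(N5CCNCC5)cn4)nc3n2C2CCCC2)c(OC)c1` follows from compound 2 with 2,4-dimethoxyphenyl in place of 3-methoxyphenyl on an amide-type nitrogen.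

Among the compounds with values here, one measured step bears on this change: a 1.4-fold higher number from compound 1 to compound 2 (0.16 log units; within the scatter). It also swaps the group on the amide-type nitrogen, but it keeps a single methoxy group, so it is only a partial guide to the new group. In this assay, on these data alone, no shift beyond the scatter is therefore expected, and the direction remains open. The expected step is a 1.2-fold lower number from compound 2 to compound 3 (0.08 log units; within the scatter). The estimate for compound 3 is 2200 nM, with an expected range of 900 nM to 5000 nM.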

Compound 3, half-maximal inhibitory concentration: 2230 nM
For compound 3 the middle estimate is 1.0-fold (0.01 log units) below the measured one; the measured number falls inside the stated range.
By their numbers in this assay, from the lowest: compounds 1, 3 and 2 (each within the scatter of the next).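

In this assay the amide-type nitrogen carries 2,4-dimethoxyphenyl in place of 3-methoxyphenyl with only a small step (a 1.2-fold lower number from compound 2 to compound 3 (0.07 log units; within the scatter)). The more direct reading comes from methoxy in place of hydrogen on an aromatic carbon (a 1.2-fold higher number from compound 1 to compound 3 (0.09 log units; within the scatter)), which shows what the two single-methoxy compounds could not: a second methoxy group on this ring produces no shift beyond the scatter. Nothing available explains why these steps are so small.

The compounds shown leave open whether a group of another kind on this ring, such as an amine or a carboxylic acid, would shift the number beyond the scatter. On these data alone, the rest of the core is the same in all three compounds, so the effect of changes elsewhere also remains open.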